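The source may report more compounds than this note shows. Statements on the series, on what has been measured and on what is new or still open speak of the compounds shown alone.

Measured so far in a functional assay for inhibition, with Homo sapiens as the target; on this read-out higher numbers stand for an effect only at larger amounts of compound and lower numbers for an effect already at smaller amounts:

- compound 1 `Nc1ccc(C2=NNC(=O)CC2)cc1`: 46.4 ug/mL
- compound 2 `CN1N=C(c2ccc(N)cc2)CCC1=O`: > 46.4 ug/mL (a limit, not a number)

Among the measured compounds shown here, compound 1 holds the only true number so far, so it has no range of other numbers to be placed against. Compound 2 gives only (the limit of > 46.4 ug/mL in this assay, at which 1 of the 2 values shown sits).

The next compound, compound 3 `CC(Cl)C(=O)Nc1ccc(C2=NNC(=O)CC2)cc1`, is built from compound 1 by the change ((1-chloroethyl)carbonyl in place of hydrogen on a nitrogen on an aromatic ring). The amino group thus becomes ((1-chloroethyl)carbonyl)amino.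

For the measured compounds named here, only one measured step can guide the expectation: methyl in place of hydrogen on an amide-type nitrogen in a ring, which gave a number no lower from compound 1 to compound 2 (the limit leaves the size open). That step has no readable size and acts on a different nitrogen, one that compound 3 leaves untouched. It therefore offers only weak guidance, and the data hold no measured change on the nitrogen on the aromatic ring.

A modest move toward lower numbers is a tentative expectation, stated as a 1.9-fold lower number from compound 1 to compound 3 (0.27 log units; within the scatter), and no change at all would be equally unsurprising. For compound 3 the estimated value is 25 ug/mL, with an expected range from 6 ug/mL to 90 ug/mL.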

Compound 3, half-maximal effective concentration: 0.45 ug/mL
The estimate for compound 3 lay 56-fold (1.74 log units) above the measured number; measured number below the stated range.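

In this assay, the nitrogen on an aromatic ring proves to be a place where a single change can matter a great deal: putting (1-chloroethyl)carbonyl in place of hydrogen there gives a 100-fold lower number from compound 1 to compound 3 (2.01 log units; beyond the scatter). The earlier pair could not show this, as the value of compound 2 is a limit rather than a number, so its step cannot be read, and its change lies on the amide-type nitrogen in a ring, which compound 3 leaves untouched. Compound 3 also shows that the amino group of compound 1 need not stay free for an effect in this assay, and that a group of this size on that nitrogen goes with an effect at much smaller amounts.

Nothing in the data shown explains why this step is so large. The compounds shown do not separate the chlorine from the carbonyl, and a plain acetyl group or a longer chain on the same nitrogen would be needed to tell which part goes with the lower number.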